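From Ethyl to Isopropyl on an Unchanged Baseline

The source may report more compounds than this note shows. Statements on the series, on what has been measured and on what is new or still open speak of the compounds shown alone.

Compound 2 `CCc1ccccc1NC(=O)N[C@@H](C)c1ccccc1` stands level with compound 1 `CCc1ccccc1NC(=O)N[C@H](C)c1ccccc1` in an ADME assay on the whole organism with Oryza sativa as the target, tested at 1 uM; a higher number here means a weaker effect of the compound at the concentration tested, a lower number a stronger effect: in that assay compound 2 gives 100% and compound 1 gives 100%. Going by the values given here, the only measured step, no change at the digits printed from compound 1 to compound 2 (within the scatter), is accounted for by the fact that compounds 1 and 2 differ only in the configuration as drawn and shows nothing beyond the scatter. Compound 3 `CC(C)c1ccccc1NC(=O)N[C@@H](C)c1ccccc1` differs from compound 2 by methyl in place of hydrogen on a saturated chain carbon bound to an aromatic carbon and a saturated chain carbon. Among the compounds with values here, no measured step touches that part of the structure, so the single step known gives no direction to borrow; it shows only that the read-out in this assay sits at its top value for this core in both measured compounds. The expected step is no change at the digits printed from compound 2 to compound 3 (within the scatter), none beyond the scatter. Compound 3 is therefore estimated at 100% in this assay, with a range from 85% to 100%.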

Compound 3, a percentage reported as activity, at one concentration (the size of the read-out at that concentration, not a potency): 96%
Compound 3: the middle estimate sits 4 percentage points above what was measured, within the range that was stated.
By their numbers in this assay, from the lowest: compounds 3, 1 and 2 (each within the scatter of the next).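

The step at this position, methyl in place of hydrogen on a saturated chain carbon bound to an aromatic carbon and a saturated chain carbon, gives a number 4 percentage points lower from compound 2 to compound 3 (within the scatter) in this assay. Going by these compounds alone, the earlier pair differed only in configuration as drawn, so this is the first reading of a change in the ethyl group itself, and going from ethyl to isopropyl leaves compound 3 within the scatter of compound 2. Nothing on hand bears on why this step has the size it has.

From the compounds shown here alone, it remains open whether any other group here, such as a tert-butyl, a cyclopropyl ring or a methoxy, would move the read-out beyond the scatter in this assay. Going by these compounds, it also remains open whether isopropyl with the opposite configuration as drawn would read the same.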